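Naphthalen-2-yl in place of naphthalen-1-yl on the shared core

This account rests on a few compounds, and the source may have more. Where it says the series, first, only, none or still open, it means among the compounds named here.

In a functional assay on Jurkat cells (Homo sapiens) for cytotoxicity, with a stated time of 48 h (a higher number here means a weaker inhibitor, a lower number a stronger inhibitor), the bromo compound 1 (`CCOC(=O)CC1C(C(=O)OCC)=C(N)Oc2ccc(Br)cc21`) gives 57300 nM. Compound 2 (`CCOC(=O)CC1C(C(=O)OCC)=C(N)Oc2ccc(-c3ccc(C(C)(C)C)cc3)cc21`), which carries 4-(tert-butyl)phenyl instead, gives 35500 nM, and the step of a 1.6-fold lower number from compound 1 to compound 2 (0.21 log units; within the scatter) stays within the scatter. Compound 3 (`CCOC(=O)CC1C(C(=O)OCC)=C(N)Oc2ccc(-c3cccc4ccccc34)cc21`), bearing naphthalen-1-yl, gives 5830 nM, the lowest of the three numbers. It stands apart from both others, with the steps of a 9.8-fold lower number from compound 1 to compound 3 (0.99 log units; beyond the scatter) and a 6.1-fold lower number from compound 2 to compound 3 (0.78 log units; beyond the scatter) each beyond the scatter.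

Compound 4 (`CCOC(=O)CC1C(C(=O)OCC)=C(N)Oc2ccc(-c3ccc4ccccc4c3)cc21`) has naphthalen-2-yl in place of naphthalen-1-yl on an aromatic carbon. Among the measured compounds shown here, the two have the same atoms, joined differently, and no measured pair tests this change directly. The nearest guide is the exchange of one aromatic group for another, a 6.1-fold lower number from compound 2 to compound 3 (0.78 log units; beyond the scatter), which shows that such an exchange can move the number modestly. The step of a 9.8-fold lower number from compound 1 to compound 3 (0.99 log units; beyond the scatter) shows what naphthalen-1-yl gained over bromo, and that gain may not carry over in full. The expected step is a 1.7-fold higher number from compound 3 to compound 4 (0.23 log units; within the scatter), a small rise in the number that stays within the scatter, though a larger move in either direction is possible. Compound 4 is estimated at 10000 nM, with an expected range from 3500 nM to 28000 nM.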

Compound 4, half-maximal inhibitory concentration: 18700 nM
The estimate for compound 4 lay 1.9-fold (0.27 log units) below the measured number, and the stated range covers the measured number.
By their numbers in this assay, from the lowest: compound 3; then compounds 4, 2 and 1 (each within the scatter of the next, the first and the last beyond it).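

Exchanging naphthalen-1-yl for naphthalen-2-yl keeps the same atoms, joined differently, yet in this assay it gives a 3.2-fold higher number from compound 3 to compound 4 (0.51 log units; beyond the scatter) and so shows that at this aromatic carbon the way the two-ring group is joined matters, and not only which atoms it brings. With naphthalen-2-yl the distance from the bromo compound is a 3.1-fold lower number from compound 1 to compound 4 (0.49 log units; beyond the scatter) and the distance from the 4-(tert-butyl)phenyl compound is a 1.9-fold lower number from compound 2 to compound 4 (0.28 log units; within the scatter) so that, among the four compounds, only naphthalen-1-yl stands apart from all the other groups at this position. Nothing shown here gives a reason for the difference between the two naphthalenyl groups.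

Going by these compounds, it remains open whether a quinolinyl group, which puts a ring nitrogen into the two-ring system, would follow naphthalen-1-yl or naphthalen-2-yl in this assay at this position. On these data alone, it is also open how an amine or a carboxylic acid added to naphthalen-1-yl would change the number, and whether the same order would hold with a different ester chain on the shared core.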